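The source may report more compounds than this note shows. Statements on the series, on what has been measured and on what is new or still open speak of the compounds shown alone.

Measured in a functional assay on HeLa cells (Homo sapiens) for antiproliferative activity, read by MTT assay, with a stated time of 48 h; on this read-out lower numbers stand for stronger inhibition and higher numbers for weaker inhibition:

Compound 1 `O=C(/C=C/c1ccccc1)Nc1cc2c(Nc3ccc(Cl)c(Cl)c3)ncnc2s1`: 430 nM
Compound 2 `O=C(/C=C/c1ccccc1)Nc1cc2ncnc(Nc3cc(Cl)cc(Cl)c3)c2s1`: 3210 nM
Compound 3 `O=C(/C=C/c1ccccc1)Nc1cc2c(Nc3cc(Cl)cc(Cl)c3)ncnc2s1`: 4 nM

Compound 3 carries the lowest number of the three. The change 3,4-dichlorophenyl in place of 3,5-dichlorophenyl on a nitrogen on an aromatic ring gave a 110-fold higher number from compound 3 to compound 1 (2.03 log units; beyond the scatter). Compound 2 shares its atoms with compound 3, but the difference between the two cores is not broken down here; compound 2 gives the highest number of the set.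

Compound 4 `O=C(/C=C/c1ccccc1)Nc1cc2ncnc(Nc3ccc(Cl)c(Cl)c3)c2s1` is still to be measured. It differs from compound 2 by 3,4-dichlorophenyl in place of 3,5-dichlorophenyl on a nitrogen on an aromatic ring, the same change as that from compound 3 to compound 1, at a place described in identical words. On that model a step of about a 9.3-fold higher number from compound 2 to compound 4 (0.97 log units; beyond the scatter) is expected in this assay, with the caveat that the core of compound 2 is not that of compound 3, so the size may not carry over. The estimate for compound 4 is 30000 nM, with a plausible span from 5000 nM to 200000 nM; a value this high may be reported only as a limit.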

Compound 4, half-maximal inhibitory concentration: 10700 nM
Estimate against measurement, compound 4: 2.8-fold (0.45 log units) above; the measured number falls inside the stated range.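

In this assay, 3,4-dichlorophenyl in place of 3,5-dichlorophenyl on the core of compound 2 gives a 3.3-fold higher number from compound 2 to compound 4 (0.52 log units; beyond the scatter). The higher number appears on both cores, so the direction of this change carries over within this pair of cores, but two cores cannot show how it would behave on a third, and the data do not explain the difference in size. The size of the step does not transfer from one core to the other: the same change on two cores in this assay, a 110-fold higher number (2.03 log units; beyond the scatter) from compound 3 to compound 1 and a 3.3-fold higher number (0.52 log units; beyond the scatter) from compound 2 to compound 4, 32-fold (1.51 log units) apart, beyond the scatter of two such steps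

Going by these compounds, whether methoxy or trifluoromethyl groups on the phenyl ring would show the same dependence on the core remains open. So does whether a single chlorine would show it.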